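Bromine to Methoxy on a Spirocyclic Lactone Scaffold

This account rests on a few compounds, and the source may have more. Where it says the series, first, only, none or still open, it means among the compounds named here.

The measured compounds:
compound 1, `COc1cc(C2=NO[C@]3(C2)C(=O)O[C@@H]2[C@H]3CC[C@H](C)[C@]3(O)C=CC(=O)[C@@]23C)ccc1O`, 0.75
compound 2, `Cc1cccc(C2=NO[C@]3(C2)C(=O)O[C@@H]2[C@H]3CC[C@H](C)[C@]3(O)C=CC(=O)[C@@]23C)c1`, 1.86
compound 3, `C[C@H]1CC[C@@H]2[C@@H](OC(=O)[C@]23CC(c2ccc(Br)cc2)N(c2ccccc2)O3)[C@]2(C)C(=O)C=C[C@@]12O`, 4

In a physicochemical assay for lipophilicity (on this read-out higher numbers stand for higher lipophilicity and lower numbers for lower lipophilicity), compound 3 stands highest of the three numbers; compound 2 lies nearest, and compound 1 furthest, both beyond the scatter. Compound 4, `COc1cccc(C2C[C@@]3(ON2c2ccccc2)C(=O)O[C@@H]2[C@H]3CC[C@H](C)[C@]3(O)C=CC(=O)[C@@]23C)c1`, has not yet been measured. It differs from compound 3 in one place: 3-methoxyphenyl in place of 4-bromophenyl on a saturated ring carbon.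

Within the data shown here, only one step has been measured so far, a number 1.11 log units higher from compound 1 to compound 2 (beyond the scatter), and it concerns a different pair of groups on a carbon with a double bond to nitrogen, not a saturated ring carbon. Among the measured compounds shown here, no measured step therefore covers the exchange of a bromine-bearing phenyl for a methoxy-bearing one. For the measured compounds named here, what can be said is that compound 3, the only compound carrying 4-bromophenyl, gives the highest number in this assay, and that the methoxy-bearing compound 1 gives the lowest. On that basis compound 4 is expected to sit below compound 3, with the step of a number 0.90 log units lower from compound 3 to compound 4 (beyond the scatter) estimated to be beyond the scatter and downward. The estimate for compound 4 in this assay is 3.1, with a range from 2.5 to 3.7.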

Compound 4, partition coefficient: 3.25
For compound 4 the middle estimate is 0.15 log units below the measured one; the measured number falls inside the stated range.
By their numbers in this assay, from the lowest: compound 1; then compound 2; then compound 4; then compound 3.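

In this assay, among these compounds, the exchange of 4-bromophenyl for 3-methoxyphenyl on a saturated ring carbon gives a number 0.75 log units lower from compound 3 to compound 4 (beyond the scatter) and so provides the only measured step at this position. The earlier step concerned a carbon with a double bond to nitrogen, so the result adds that the read-out also responds to a change at this saturated ring carbon, although the step here is modest. Among the compounds shown here, the change is a composite one, since the bromine is lost, a methoxy group enters, the substituent's place on the phenyl ring differs, and a hydrogen-bond acceptor is added, so the single step gives no separate share to any of these.

The compounds shown leave open how much of the step belongs to the substituent and how much to its place on the phenyl ring, a question that 3-bromophenyl or 4-methoxyphenyl at this carbon would address. They also leave open how this position responds to a group of another kind, such as an amine or a carboxylic acid on the phenyl ring. No supporting evidence is available to explain the step.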